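The source may hold more compounds than are shown below. What is called first, only, known or untested is meant among the compounds shown, and "the series" means these compounds.

Measured in a functional assay on Bel-7402 cells (Homo sapiens) for inhibition, read by sulforhodamine B assay, with a stated time of 72 h; a higher number here means a weaker inhibitor, a lower number a stronger inhibitor:
- compound 1 `C[C@H](Nc1ncnc2[nH]cnc12)c1nn(-c2cccc(F)c2)c2cc(F)ccc12`: > 40000 nM
- compound 2 `C[C@H](Nc1nc(N)nc(N)c1C#N)c1nn(-c2cccc(S(C)(=O)=O)c2)c2cc(Cl)ccc12`: 4460 nM
- compound 3 `C[C@H](Nc1nc(N)nc(N)c1C#N)c1nn(-c2cccnc2)c2cc(C(F)(F)F)ccc12`: 3190 nM

Compound 1 has no numerical result, only the limit of > 40000 nM. This is the evidence for its position: the limit of > 40000 nM in this assay, at which 1 of the 3 values shown sits. Compound 2 gives 4460 nM and compound 3 gives 3190 nM, and both are actual numbers, but each differs from compound 1 in more than one place.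

Compound 4 `C[C@H](Nc1ncnc2[nH]cnc12)c1nn(-c2ccncc2)c2cc(F)ccc12` is the next entry to be read. It has pyridin-4-yl in place of 3-fluorophenyl on an aromatic nitrogen of a five-membered aromatic ring, and the rest of compound 1 is unchanged: pyridin-4-yl in place of 3-fluorophenyl on an aromatic nitrogen.

Going by the values given here, no measured pair differs in one place, so there is no direct guide to the size of this step. The working expectation in this assay is a small step with no firm direction, and another result reported only as a limit is the likeliest outcome. The estimated step is an at least 1.3-fold lower number from compound 1 to compound 4 (0.12 log units; that floor lies within the scatter), and it is uncertain because compound 1 stands at > 40000 nM. Compound 4 is expected at 30000 nM, with an estimated range from 10000 nM to 60000 nM.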

Compound 4, half-maximal inhibitory concentration: > 40000 nM
Compound 4 was reported as a limit; the forecaster's own chance of this, stated with the estimate: 60%; at least 1.3-fold (0.12 log units) between middle value and limit.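

Compound 1 and compound 4 are both reported only as limits in this assay, so no step can be read from the exchange of 3-fluorophenyl for pyridin-4-yl: the limit of > 40000 nM in this assay, at which 2 of the 4 values shown sit.

The compounds shown leave open whether pyridin-4-yl in place of 3-fluorophenyl on an aromatic nitrogen changes inhibition on the shared core at all, and in which direction.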